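The source may hold more compounds than are shown below. What is called first, only, known or untested is meant among the compounds shown, and "the series" means these compounds.

Among the measured compounds shown here, in a functional assay on A2780 cells (Homo sapiens) for antiproliferative activity, read by MTT assay, with a stated time of 48 h (a higher number here means a weaker inhibitor of growth, a lower number a stronger inhibitor of growth), compound 2 (`COC(=O)N1N=C(c2cccc(O)c2)CC1c1cc(OC)c(OC)c(OC)c1`) gives 810 nM and compound 3 (`CCOC(=O)N1N=C(c2cccc(O)c2)CC1c1cc(OC)c(OC)c(OC)c1`) gives 9750 nM, the higher of the two numbers measured so far. Compound 1 (`COc1cccc(C2=NN(C(=O)OCc3ccccc3)C(c3cc(OC)c(OC)c(OC)c3)C2)c1`), which carries benzyloxycarbonyl but also differs elsewhere, reads > 10000 nM, and this is a limit of the assay and not a number.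

Compound 4 (`COc1cc(C2CC(c3cccc(O)c3)=NN2C(=O)OCc2ccccc2)cc(OC)c1OC`) departs from compound 3 by one change: phenyl in place of methyl on a saturated chain carbon bound to an oxygen next to a carbonyl group. In words, this is phenyl in place of methyl on a saturated chain carbon bound to an oxygen next to a carbonyl group, so that ethoxycarbonyl becomes benzyloxycarbonyl.

For the measured compounds named here, only one measured step bears directly on this place. It is a 12-fold higher number from compound 2 to compound 3 (1.08 log units; beyond the scatter), a large step that came with methyl in place of hydrogen at the same carbon. The direction of that step suggests that further growth of the chain should again raise the number. However, compound 3 already stands high, and the limit seen for compound 1 suggests little room for a measurable change, so only a small move upward is expected in this assay.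

The expected change is a 1.3-fold higher number from compound 3 to compound 4 (0.12 log units; within the scatter). For compound 4 the estimated value is 13000 nM, with an expected range of 4000 nM to 40000 nM.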

Compound 4, concentration for 50% growth inhibition: > 10000 nM
Compound 4 gave a limit, no number; the forecaster's own chance of this, stated with the estimate: 55%; the middle value is on the limit's open side.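

At the saturated chain carbon bound to an oxygen next to a carbonyl group, phenyl does not bring back the lower number of compound 2 in this assay: the reading is an at least 12-fold higher number from compound 2 to compound 4 (1.09 log units; beyond the scatter), so the large rise seen with methyl at this carbon also holds for the larger group. Against compound 3 the reading is an at least 1.0-fold higher number from compound 3 to compound 4 (0.01 log units; that floor lies within the scatter), so phenyl is not shown to add anything to the effect of methyl, and how far compound 4 lies past compound 3 remains unknown. The step between compound 1 and compound 4 cannot be read, which leaves hydrogen in place of methyl on an oxygen on an aromatic ring without a measured effect at this limit: the limit of > 10000 nM in this assay, at which 2 of the 4 values shown sit.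

Going by these compounds, only compound 2 and compound 3 give numbers at this place, so it remains open whether the number climbs steadily as the group at this carbon grows or simply stays high once hydrogen is replaced. Also open, on these data alone, is whether a longer chain such as propyl, or an amine at the same carbon, would give a number inside the readable range of this assay.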